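Dropping the chloro from a nitrobenzyl oxime ether

A few compounds are considered here, and "the series" means these few. Any claim that something is new, unique, unknown or untested is made for them only; others in the source may bear on it.

Within the data shown here, compound 2 `Cc1nn(C)c(Oc2ccc(Cl)cc2)c1/C=N/OCc1ccc([N+](=O)[O-])cc1` has the lowest of the two numbers measured so far in a functional assay on HepG2 cells (Homo sapiens) for antiproliferative activity, tested at 1 uM (on this read-out lower numbers stand for less inhibition and higher numbers for more inhibition at the one concentration tested (going by the name of the read-out)), giving 18.4%. Among the measured compounds shown here, its nearest neighbour is compound 1 `CCOC(=O)c1ccc(CO/N=C/c2c(C)nn(C)c2Oc2ccc(Cl)cc2)cc1`, which in this assay gives 27.4%; the one measured step, a number 9 percentage points lower from compound 1 to compound 2 (within the scatter), exchanges the group on the benzyl ring and stays within the scatter. Compound 3 `Cc1nn(C)c(Oc2ccccc2)c1/C=N/OCc1ccc([N+](=O)[O-])cc1` is not yet measured. It differs from compound 2 by hydrogen in place of chloro on an aromatic carbon, that is, 4-chlorophenoxy becomes phenoxy. No measured step touches this ring, so nothing shown speaks to the size or direction of the change; the only step known, at the other ring, was within the scatter. The step from compound 2 to compound 3 is therefore expected to be small, a number 2.4 percentage points lower from compound 2 to compound 3 (within the scatter). Compound 3 is estimated at 16%, with a range from 4% to 30%.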

Compound 3, a percentage reported as inhibition, at one concentration (the size of the read-out at that concentration, not a potency): -2.8%
Estimate against measurement, compound 3: 18.8 percentage points above, outside the stated range (below it).
By their numbers in this assay, from the lowest: compound 3; then compounds 2 and 1 (each within the scatter of the next).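

Among these compounds, the change from 4-chlorophenoxy to phenoxy produces a number 21.2 percentage points lower from compound 2 to compound 3 (beyond the scatter) in this assay and is the only step so far to lie beyond the scatter, whereas the exchange on the benzyl ring gave a number 9 percentage points lower from compound 1 to compound 2 (within the scatter) and stayed within it. Among the compounds shown here, the chloro on this ring therefore counts for more than the earlier compounds could show, and without it compound 3 gives -2.8% at the one concentration tested. Nothing available explains the change.

The compounds shown leave open whether a bromo, methyl or methoxy group in the same place would keep the number of compound 2 or lose it as hydrogen does. They also leave open whether hydrogen in place of chloro would bring a similar step in compound 1, which carries the ethoxycarbonyl group.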